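Pyridinyl for fluorophenyl on a piperazine dithiocarbamate

This account rests on a few compounds, and the source may have more. Where it says the series, first, only, none or still open, it means among the compounds named here.

Measured compounds:
compound 1 `Nc1ccccc1NC(=O)c1ccc(CSC(=S)N2CCN(c3ccc(F)cc3)CC2)cc1` with 48.7%
compound 2 `Nc1ccccc1NC(=O)c1ccc(CSC(=S)N2CCN(c3ccccc3F)CC2)cc1` with 86.4%

In a functional assay on MGC-803 cells (Homo sapiens) for antiproliferative activity, read by CCK-8 assay, with a stated time of 72 h, tested at 8 uM (on this read-out lower numbers stand for a weaker effect and higher numbers for a stronger effect at the one concentration tested), compound 2 gives 86.4%, the highest of the two numbers; its nearest neighbour, compound 1, gives 48.7%. Going by the values given here, the single step between them, a number 37.7 percentage points higher from compound 1 to compound 2 (beyond the scatter), shows that the group on the amine nitrogen in the ring can move this read-out by a large amount.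

Compound 3 `Nc1ccccc1NC(=O)c1ccc(CSC(=S)N2CCN(c3ccncc3)CC2)cc1` is not yet measured. It differs from compound 2 in one place: pyridin-4-yl in place of 2-fluorophenyl on an amine nitrogen in a ring. Among the compounds with values here, no measured step replaces this aromatic ring by one with a hetero atom, so the only guidance is that the step from compound 1 to compound 2 was large when the same position was altered. Because the swap of the fluorine position alone produced a number 37.7 percentage points higher from compound 1 to compound 2 (beyond the scatter), the present change is expected to shift this assay by a comparable amount, most likely downward, though the direction is uncertain. Compound 3 is therefore estimated to give 55%, within 25% to 85%, a step of a number 31.4 percentage points lower from compound 2 to compound 3 (beyond the scatter) that is expected rather than known.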

Compound 3, a percentage reported as inhibition, at one concentration (the size of the read-out at that concentration, not a potency): 87.1%
The estimate for compound 3 lay 32.1 percentage points below the measured number, outside the stated range (above it).
By their numbers in this assay, from the lowest: compound 1; then compounds 2 and 3 (each within the scatter of the next).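

In this assay, compound 2 and compound 3 cannot be told apart, with a number 0.7 percentage points higher from compound 2 to compound 3 (within the scatter), so on this amine nitrogen in a ring, pyridin-4-yl serves as well as 2-fluorophenyl, even though it has a ring nitrogen and a hydrogen-bond acceptor and no fluorine. Pyridin-4-yl also stands well clear of 4-fluorophenyl, with a number 38.4 percentage points higher from compound 1 to compound 3 (beyond the scatter), which shows that among these three compounds a group need not carry fluorine to reach the high level, and that compound 1 alone gives the low number. Nothing measured on these compounds accounts for this result.

The compounds shown leave open whether pyridin-3-yl or pyridin-2-yl, which carry the ring nitrogen elsewhere, or a non-aromatic group such as cyclohexyl or a plain methyl on the same nitrogen would hold this read-out. Since this assay reports a single concentration, they also leave open whether compound 2 and compound 3 would stay together at lower concentrations, where one of them could still show a stronger effect than the other.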